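Chloro-to-amino exchange at the fused ring of compound 2

The source may report more compounds than this note shows. Statements on the series, on what has been measured and on what is new or still open speak of the compounds shown alone.

Compound 1 `Nc1nn(C(=O)Nc2ccc(Cc3ccccc3)cc2)c2ccccc12` is the unsubstituted parent of the pair. In a functional assay on T47D cells (Homo sapiens) for antiproliferative activity, read by sulforhodamine B assay, with a stated time of 48 h (a lower number here means a stronger inhibitor of growth, a higher number a weaker inhibitor of growth), compound 1 gives > 100000 nM, a limit of the assay and not a number. Among the compounds with values here, compound 2 `Nc1nn(C(=O)Nc2ccc(Cc3ccccc3)cc2)c2ccc(Cl)cc12` carries a chloro on the fused benzene ring; in this assay compound 2 gives 27600 nM, the only true number in the set so far. The other entry, that of compound 1, sits at the limit (the limit of > 100000 nM in this assay, at which 1 of the 2 values shown sits). Within the data shown here, the one measured step, an at least 3.6-fold lower number from compound 1 to compound 2 (0.55 log units; beyond the scatter), shows that putting a group at this carbon moved the number. Compound 3 `Nc1ccc2c(c1)c(N)nn2C(=O)Nc1ccc(Cc2ccccc2)cc1` differs from compound 2 by amino in place of chloro on an aromatic carbon. Among the measured compounds shown here, no measured step covers amino at this position, so the direction is open; the change from hydrogen to chloro gave the only gain seen, and amino is a different substituent. For compound 3 the expected step is a 1.8-fold higher number from compound 2 to compound 3 (0.26 log units; within the scatter), toward a weaker inhibitor. Compound 3 is estimated at 50000 nM in this assay, with a range from 15000 nM to 200000 nM.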

Compound 3, concentration for total growth inhibition: 22800 nM
Beside the measured number, compound 3's estimate is 2.2-fold (0.34 log units) above it; measured number inside the range.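

Exchange of chloro for amino in this assay gives a 1.2-fold lower number from compound 2 to compound 3 (0.08 log units; within the scatter) and so separates neither group from the other at this position. Amino in place of hydrogen gives an at least 4.3-fold lower number from compound 1 to compound 3 (0.64 log units; beyond the scatter) and is thus the second group on this aromatic carbon, after chloro, to stand clear of the unsubstituted parent, although amino brings a hydrogen-bond donor and acceptor that chloro does not. The size of that gain has no upper end, as compound 1 stands at a limit and not at a number: the limit of > 100000 nM in this assay, at which 1 of the 3 values shown sits.

Still open, on these data alone, is whether any group on this carbon gives the same result, or whether a carboxylic acid or a methoxy group would fall back toward compound 1. Also open, as far as these compounds go, is whether a longer chain here would move the number beyond the level shared by compound 2 and compound 3.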